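Switching the chloroalkyl amide for a chloropyridine

The compounds below may be only part of what the source reports. "The series", "measured", "known", "first", "only" and "open" are said of these compounds alone.

The three measured compounds share one core, carrying an amide whose acyl part varies. Compound 1 `O=C(CCl)Nc1cccc(-c2nc3ccccc3s2)c1` bears a chloromethyl group on the carbonyl carbon; in an ADME assay on HEK293 cells (Homo sapiens) for inhibition, with a stated time of 72 h (on this read-out higher numbers stand for an effect only at larger amounts of compound and lower numbers for an effect already at smaller amounts), compound 1 gives 10000 nM. Compound 2 `CC(Cl)C(=O)Nc1cccc(-c2nc3ccccc3s2)c1` adds a methyl on the chain carbon that carries the chlorine. In this assay compound 2 reaches only a limit, > 25000 nM. Compound 3 `CC(C)(CCl)C(=O)Nc1cccc(-c2nc3ccccc3s2)c1` carries a 1-(chloromethyl)-1-methylethyl group on the carbonyl carbon. For compound 3 this assay likewise reports only a limit, > 25000 nM. The steps read an at least 2.5-fold higher number from compound 1 to compound 2 (0.39 log units; beyond the scatter) and an at least 2.5-fold higher number from compound 1 to compound 3 (0.39 log units; beyond the scatter), while the step that the two limits leave unreadable from compound 2 to compound 3 cannot be sized. Compound 3 thus stands at the top of the shown numbers, together with compound 2, on (the limit of > 25000 nM in this assay, at which 2 of the 3 values shown sit).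

Compound 4 `O=C(Nc1cccc(-c2nc3ccccc3s2)c1)c1cnccc1Cl` differs from compound 3 in one place: 4-chloropyridin-3-yl in place of 1-(chloromethyl)-1-methylethyl on a carbonyl carbon. For the measured compounds named here, no measured step exchanges a saturated chloroalkyl group for an aromatic ring here, so neither step an at least 2.5-fold higher number from compound 1 to compound 2 (0.39 log units; beyond the scatter) nor step an at least 2.5-fold higher number from compound 1 to compound 3 (0.39 log units; beyond the scatter) bears directly on it; they only show that compound 3 starts from a limit. Any step from compound 3 to compound 4 is therefore an expectation only, and the expected step is an at least 1.2-fold lower number from compound 3 to compound 4 (0.09 log units; that floor lies within the scatter). In this assay compound 4 is estimated at 20000 nM, within a range from 5000 nM to 50000 nM.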

Compound 4, half-maximal effective concentration: > 25000 nM
Compound 4 was reported as a limit; the forecaster's own chance of this, stated with the estimate: 55%; middle value at least 1.2-fold (0.09 log units) from the limit.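

The aromatic 4-chloropyridin-3-yl group on the carbonyl carbon, not only a further substituted saturated chain, moves the read-out away from that of the chloromethyl group, with an at least 2.5-fold higher number from compound 1 to compound 4 (0.39 log units; beyond the scatter). Among the four compounds in this assay, chloromethyl is thus the only group on this carbon that yields a number rather than a limit, and no compound shown goes against this: the limit of > 25000 nM in this assay, at which 3 of the 4 values shown sit. The steps from compound 2 and from compound 3 to compound 4 cannot be read, since both ends of each are limits, so the chloropyridine cannot be ranked against the two branched chloroalkyl groups.

What the compounds shown leave open is how much of the read-out of compound 1 depends on the chlorine itself, which an acetyl group on the carbonyl carbon or a pyridin-3-yl ring carrying no chlorine would address. Also open, as far as these compounds go, is whether a longer chain such as 3-chloropropyl would stay at a readable number like compound 1 or join the limit shared by the other three.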